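Series notes: amino addition on the core of compound 1

This account rests on a few compounds, and the source may have more. Where it says the series, first, only, none or still open, it means among the compounds named here.

Compound 1 `COc1ncnc2c1c(-c1cccs1)cn2[C@@H]1O[C@H](CO)[C@@H](O)[C@H]1O` gives 4850 nM in a functional assay on A549 cells (Homo sapiens), read by MTT assay, with a stated time of 72 h; a higher number here means a weaker inhibitor, a lower number a stronger inhibitor. Compound 2 `CNc1ncnc2c1c(-c1cccs1)cn2[C@@H]1O[C@H](CO)[C@@H](O)[C@H]1O` returns only a limit, > 20000 nM. Compound 3 `CN(C)c1ncnc2c1c(-c1cccs1)cn2[C@@H]1O[C@H](CO)[C@@H](O)[C@H]1O` likewise returns only a limit, > 20000 nM.

Among the compounds with values here, compound 1 thus holds the only numeric value in this assay; the other two results are the limit of > 20000 nM in this assay, at which 2 of the 3 values shown sit. Replacing its methoxy group gives an at least 4.1-fold higher number from compound 1 to compound 2 (0.61 log units; beyond the scatter) and an at least 4.1-fold higher number from compound 1 to compound 3 (0.61 log units; beyond the scatter), while from compound 2 to compound 3 the two limits leave a step that the two limits leave unreadable from compound 2 to compound 3.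

Compound 4 `COc1nc(N)nc2c1c(-c1cccs1)cn2[C@@H]1O[C@H](CO)[C@@H](O)[C@H]1O` keeps the methoxy group of compound 1 and differs by amino in place of hydrogen on an aromatic carbon. Within the data shown here, none of the measured steps touches this position: all three alter the methoxy group, which compound 4 retains. No measured evidence therefore points to a direction, and the expectation rests on compound 1 alone. The expected step is a 1.0-fold higher number from compound 1 to compound 4 (0.01 log units; within the scatter), within the scatter. Compound 4 is estimated at 5000 nM, with a range from 1500 nM to 20000 nM, and a real chance that this assay again reports only a limit.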

Compound 4, half-maximal inhibitory concentration: > 20000 nM
Compound 4 gave a limit, no number; the forecaster's own chance of this, stated with the estimate: 25%; middle value at least 4.0-fold (0.60 log units) away from the limit.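

Amino in place of hydrogen on the aromatic carbon between two ring nitrogen atoms gives an at least 4.1-fold higher number from compound 1 to compound 4 (0.61 log units; beyond the scatter). This is the first change shown away from the methoxy group, and it too moves the number beyond the scatter in this assay, so the drop in activity is not confined to changes of the methoxy group. The result for compound 4 is a limit, not a number, and compound 1 remains the only compound of the series with a numeric value: the limit of > 20000 nM in this assay, at which 3 of the 4 values shown sit.

The compounds shown leave open how large the step to compound 4 really is. Also open, on these data alone, is whether a chlorine atom or a methyl group on this same carbon would keep compound 1 at 4850 nM or move it to a higher number.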